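Urea series on the shared core: trifluoromethyl removal

The source may report more compounds than this note shows. Statements on the series, on what has been measured and on what is new or still open speak of the compounds shown alone.

Measured so far:
- compound 1, `O=C(Nc1cccc(-n2cc(-c3ccncc3)c(-c3cc(O)cc(Cl)c3)n2)c1)Nc1ccc(Cl)c(C(F)(F)F)c1`: 93%
- compound 2, `O=C(Nc1cccc(-n2cc(-c3ccncc3)c(-c3cc(O)cc(Cl)c3)n2)c1)Nc1ccc(Cl)c(Cl)c1`: 59%
- compound 3, `COc1cc(Cl)cc(-c2nn(-c3cccc(NC(=O)Nc4cc(C(F)(F)F)cc(C(F)(F)F)c4)c3)cc2-c2ccncc2)c1`: 93%

In a functional assay on HCT-15 cells (Homo sapiens) for inhibition, read by sulforhodamine B assay, with a stated time of 48 h, tested at 0.01 uM (on this read-out higher numbers stand for a weaker effect at the one concentration tested and lower numbers for a stronger effect), compound 3 gives 93%. That places it level with compound 1 at the digits recorded, the two together at the top of the three numbers, and well apart from compound 2, whose value of 59% lies far lower.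

Compound 4, `COc1cc(Cl)cc(-c2nn(-c3cccc(NC(=O)Nc4cccc(C(F)(F)F)c4)c3)cc2-c2ccncc2)c1`, has yet to be measured. It differs from compound 3 in one place: hydrogen in place of trifluoromethyl on an aromatic carbon.

Going by the values given here, only one measured step exists, a number 34 percentage points lower from compound 1 to compound 2 (beyond the scatter). That step exchanges trifluoromethyl for chloro on the same urea-bearing aryl, so it does not test the present change, in which trifluoromethyl is replaced by hydrogen while a second trifluoromethyl stays in place. Among the compounds with values here, it shows only that a single change on that aryl can move the read-out by a large amount. Within the data shown here, no measured pair covers the loss of a trifluoromethyl to hydrogen, so the direction is open; a small shift downward is taken as the more likely outcome, short of the size seen in that step.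

The expected step is therefore a number 9 percentage points lower from compound 3 to compound 4 (within the scatter). Compound 4 is estimated at 84%, with a range from 62% to 100%.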

Compound 4, a percentage reported as activity, at one concentration (the size of the read-out at that concentration, not a potency): 92%
Compound 4: the middle estimate sits 8 percentage points below what was measured; the measured number falls inside the stated range.
By their numbers in this assay, from the lowest: compound 2; then compounds 4, 1 and 3 (each within the scatter of the next).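

In this assay the step is a number 1 percentage points lower from compound 3 to compound 4 (within the scatter) for hydrogen in place of trifluoromethyl, so at this place, meta to a trifluoromethyl group, the group can leave without the two values separating beyond the scatter. The earlier change, a number 34 percentage points lower from compound 1 to compound 2 (beyond the scatter) with chloro in place of trifluoromethyl, moved the read-out far more, but it sits on a differently substituted aryl, so these notes show that a large step on this aryl is not general, and only for this pair. No data on hand bear on the reason for this outcome.

Compound 3 and compound 4 both stand at the weak end of a read-out taken at one concentration, so the pair says nothing about any difference that would appear at other concentrations. Still open, on these data alone, are whether the remaining trifluoromethyl group can also give way to hydrogen, whether an amine, a carboxylic acid or a nitrile at the vacated place would keep the read-out level, and whether the same exchange behaves alike on the hydroxy-bearing core of compound 1.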